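This account rests on a few compounds, and the source may have more. Where it says the series, first, only, none or still open, it means among the compounds named here.

Measured compounds in a functional assay on MKN-74 cells (Homo sapiens) for antiproliferative activity, with a stated time of 24 h; a lower number here means a stronger inhibitor, a higher number a weaker inhibitor:
compound 1, `NC(=O)c1c(NC(=O)c2ccccc2Cl)sc2c1CCN(Cc1ccc([N+](=O)[O-])cc1)C2`: 31500 nM
compound 2, `Cc1ccc(C(=O)Nc2sc3c(c2C(N)=O)CCN(Cc2ccc(Cl)cc2Cl)C3)cc1`: 25500 nM
compound 3, `NC(=O)c1c(NC(=O)c2cccc([N+](=O)[O-])c2)sc2c1CCN(Cc1ccc(Cl)cc1Cl)C2`: 16500 nM

Compound 1 gives the highest of the three numbers, yet its gap to compound 2 and its gap to compound 3 both fall within the usual scatter, so the three compounds are not separated by this assay. Among the compounds with values here, the one step between measured compounds, a 1.5-fold lower number from compound 2 to compound 3 (0.19 log units; within the scatter), alters the group on the carbonyl carbon and leaves the substituent on the amine nitrogen in the ring untouched.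

Compound 4, `NC(=O)c1c(NC(=O)c2ccccc2Cl)sc2c1CCN(C(=S)Nc1c(Cl)cccc1Cl)C2`, differs from compound 1 in this way: a group of 11 heavy atoms (7 carbon, 1 nitrogen, 1 sulfur, 2 chlorine; one six-membered aromatic ring of carbon only) in place of a group of 10 heavy atoms (7 carbon, 1 nitrogen, 2 oxygen; one six-membered aromatic ring of carbon only), on an amine nitrogen in a ring. Within the data shown here, no measured pair changes this position, so no step bears on the change directly. Among the measured compounds shown here, the only comparison available, a 1.5-fold lower number from compound 2 to compound 3 (0.19 log units; within the scatter), concerns another part of the shared core and is itself within the scatter. For compound 4 the expected step of a 1.3-fold lower number from compound 1 to compound 4 (0.10 log units; within the scatter) is therefore close to no change, with wide uncertainty. Compound 4 is estimated at 25000 nM in this assay, within a range from 7000 nM to 90000 nM.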

Compound 4, half-maximal inhibitory concentration: 4020 nM
Beside the measured number, compound 4's estimate is 6.2-fold (0.79 log units) above it; measured number below the stated range.
By their numbers in this assay, from the lowest: compound 4; then compounds 3, 2 and 1 (each within the scatter of the next).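

In this assay, the change on the amine nitrogen in the ring gives a 7.8-fold lower number from compound 1 to compound 4 (0.89 log units; beyond the scatter), the only step among the compounds shown that lies beyond the scatter. The earlier step concerned the group on the carbonyl carbon and stayed within the scatter, so this result gives the first sign that the numbers respond to a change in the series, and it places that response at the amine nitrogen. No measurement available here accounts for the step.

The entering group differs from 4-nitrobenzyl in several features at once, so these compounds do not show which feature carries the step. Open questions are how a urea with oxygen in place of the sulfur would compare, and how an unsubstituted phenyl ring would compare with the two-chlorine ring.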